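The source may hold more compounds than are shown below. What is called first, only, known or untested is meant among the compounds shown, and "the series" means these compounds.

Working notes on the series. In an ADME assay on HEK293 cells (Homo sapiens) for inhibition, read by MTT assay, with a stated time of 48 h, tested at 25 uM (on this read-out lower numbers stand for less inhibition and higher numbers for more inhibition at the one concentration tested (going by the name of the read-out)), compound 1 `COc1ccc(NC(=O)Cn2cc(COc3ccc4c(c3)CCC4)nn2)cc1` gives "not determined" (no result reported), and in this assay compound 2 `CCc1ccc(-n2cc(COc3ccc4c(c3)CCC4)nn2)cc1` gives "not determined" (no result reported); for compound 1 there is no number to stand on. Within the data shown here, compound 3 `Cc1cc(C)c(-n2cc(COc3ccc4c(c3)CCC4)nn2)c(C)c1` is the only measured member: in this assay compound 3 gives 16.6%. Compound 4 `COc1ccccc1NC(=O)Cn1cc(COc2ccc3c(c2)CCC3)nn1` has not yet been measured. It differs from compound 1 in one place: 2-methoxyphenyl in place of 4-methoxyphenyl on an amide-type nitrogen. Among the measured compounds shown here, no measured pair shows how this change moves this assay, and with compound 1 itself unmeasured no direction is expected beyond the scatter. Going by compound 3 and its 16.6%, compound 4 is expected to give 15% in this assay, estimated within 0% to 40%.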

Compound 4, a percentage reported as inhibition, at one concentration (the size of the read-out at that concentration, not a potency): 23.4%
Compound 4: middle estimate off by 8.4 percentage points, on the low side, within the range that was stated.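

No new step can be read between compound 1 and compound 4, as compound 1 gives no number in this assay. The compounds shown leave open how 2-methoxyphenyl in place of 4-methoxyphenyl moves this assay. Nothing available bears on this result.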